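Swapping neopentyl for oxolan-2-yl on compound 3

The source may report more compounds than this note shows. Statements on the series, on what has been measured and on what is new or still open speak of the compounds shown alone.

Compound 1 `Cc1cc(C(N)=O)nn1Cc1cc(Cl)ccc1OCc1ccccc1` gives 3.7 as a number
Compound 2 `Cc1cc(C(=O)Nc2ccccc2)nn1Cc1cc(Cl)ccc1OCc1ccccc1` gives > 3.7 as a limit
Compound 3 `Cc1cc(NC(=O)CC(C)(C)C)nn1Cc1cc(Cl)ccc1OCc1ccccc1` gives > 3.7 as a limit

In a physicochemical assay for lipophilicity, at pH 7.4 (a lower number here means a more polar compound, a higher number a more lipophilic compound), compound 3 reports only a limit (> 3.7) and no number. Compound 4 `Cc1cc(NC(=O)C2CCCO2)nn1Cc1cc(Cl)ccc1OCc1ccccc1` carries one change: oxolan-2-yl in place of neopentyl on a carbonyl carbon with oxolan-2-yl in place of neopentyl on a carbonyl carbon. The measured steps of a number no lower from compound 1 to compound 3 (the limit leaves the size open) and a step that the two limits leave unreadable from compound 2 to compound 3 have no readable size, so neither fixes a number for this change. Oxolan-2-yl brings a hydrogen-bond acceptor that neopentyl lacks, so a downward move in this assay is expected. The expected move is a step that the limit leaves unreadable from compound 3 to compound 4 and remains rough. Compound 4 may also return only a limit. Compound 4 is estimated at 3.8 (expected range 3.3 to 4.4).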

Compound 4, distribution coefficient: > 3.7
Compound 4 gave a limit, no number; the forecaster's own chance of this, stated with the estimate: 50%; the middle value does not contradict the limit.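

In this assay compound 4 gives > 3.7 as a limit, not a number. Oxolan-2-yl brings a hydrogen-bond acceptor that neopentyl lacks, yet with this swap on the carbonyl carbon the compound still has no measured number, and none of the steps to compound 4 can be read in size. Compound 4 joins the compounds that reach this ceiling: the limit of > 3.7 in this assay, at which 3 of the 4 values shown sit.

On these data alone, how large the change from neopentyl to oxolan-2-yl really is remains open. Also open, as far as these compounds go, is the size of the change from carbamoyl to ((oxolan-2-yl)carbonyl)amino, where the data give only a number no lower from compound 1 to compound 4 (the limit leaves the size open).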